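A Methoxy Added to Compound 1

The source may report more compounds than this note shows. Statements on the series, on what has been measured and on what is new or still open speak of the compounds shown alone.

Measured in a functional assay on A549 cells (Homo sapiens) for inhibition, read by MTT assay, with a stated time of 24 h (a higher number here means a weaker inhibitor of growth, a lower number a stronger inhibitor of growth), so far
Compound 1 `Cn1cc(-c2nc3ccccc3n2C(=O)c2ccccc2)c2ccccc21` gives 19600 nM
Compound 2 `COc1ccc(C(=O)n2c(-c3cn(C)c4ccccc34)nc3ccccc32)cc1` gives 10400 nM
Compound 3 `Cn1cc(-c2nc3ccccc3n2C(=O)c2ccccc2Br)c2ccccc21` gives 43200 nM

Compound 1 has compound 2 within the scatter of its number and compound 3 on its higher side. Compound 4 `COc1ccc2c(c1)c(-c1nc3ccccc3n1C(=O)c1ccccc1)cn2C` is compound 1 with methoxy in place of hydrogen on an aromatic carbon, on a six-membered aromatic ring of carbon only, part of a fused or bridged system of two rings. The nearest guide is the same exchange elsewhere in the molecule, which gave a 1.9-fold lower number from compound 1 to compound 2 (0.28 log units; within the scatter) in size. The bromo exchange gave a 2.2-fold higher number from compound 1 to compound 3 (0.34 log units; beyond the scatter) and was also small. No step beyond the scatter is therefore expected in this assay, with at most a slight lean towards a lower number. The estimated step is a 1.3-fold lower number from compound 1 to compound 4 (0.12 log units; within the scatter) in this expected direction. For compound 4 the estimate is 15000 nM, expected between 7000 nM and 32000 nM on repeated measurement.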

Compound 4, concentration for 50% growth inhibition: 16700 nM
Compound 4: the middle estimate sits 1.1-fold (0.05 log units) below what was measured; the measured number falls inside the stated range.
By their numbers in this assay, from the lowest: compounds 2, 4 and 1 (each within the scatter of the next); then compound 3.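

In this assay methoxy on this six-membered aromatic ring of carbon only, part of a fused or bridged system of two rings, gives a 1.2-fold lower number from compound 1 to compound 4 (0.07 log units; within the scatter) and so stays within the scatter. Compound 2 carries methoxy in another place and also stays within the scatter of compound 1, so neither place has yet shown a clear effect of this group. No measured evidence bears on this result.

From the compounds shown here alone, whether an amine or a carboxylic acid at this same position would move the number beyond the scatter remains open.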